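The source may hold more compounds than are shown below. What is called first, only, known or untested is meant among the compounds shown, and "the series" means these compounds.

In a functional assay on Caco-2 cells (Homo sapiens), read by MTT assay, with a stated time of 48 h (on this read-out lower numbers stand for stronger inhibition and higher numbers for weaker inhibition), compound 3 (`C#CCNC(=O)c1ccc(C(CC)(CC)c2ccc(OCC(O)C(C)(C)C)c(C)c2)n1CC`) stands highest of three at 39100 nM against compound 1 (`CCn1c(C(=O)NCCN)ccc1C(CC)(CC)c1ccc(OCC(=O)C(C)(C)C)c(C)c1`) at 1900 nM and compound 2 (`CCN(CC)CCCNC(=O)c1ccc(C(CC)(CC)c2ccc(OCC(O)C(C)(C)C)c(C)c2)n1CC`) at 1800 nM so far. Compound 4 (`CCn1c(C(=O)NCCN)ccc1C(CC)(CC)c1ccc(OCC(O)C(C)(C)C)c(C)c1`) puts aminomethyl in place of ethynyl on a saturated chain carbon bound to an amide-type nitrogen, which reads as propargyl to 2-aminoethyl. Within the data shown here, the one measured step bearing on this is large (a 22-fold higher number from compound 2 to compound 3 (1.34 log units; beyond the scatter)) and ends at the same ethynyl compound. Compound 1 already carries 2-aminoethyl but differs from compound 4 elsewhere. A large step to a lower number in this assay is therefore expected. The expected step (a 17-fold lower number from compound 3 to compound 4 (1.23 log units; beyond the scatter)) is of similar size to that measured one. Compound 4 is estimated at 2300 nM (range 800 nM to 8000 nM).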

Compound 4, half-maximal inhibitory concentration: 1000 nM
For compound 4 the middle estimate is 2.3-fold (0.36 log units) above the measured one; the range from low to high includes it.
By their numbers in this assay, from the lowest: compounds 4, 2 and 1 (each within the scatter of the next); then compound 3.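

In this assay, propargyl to 2-aminoethyl on the amide nitrogen gives a 39-fold lower number from compound 3 to compound 4 (1.59 log units; beyond the scatter), so at this position the outcome turns on the chain itself, and the chain ending in amino matches the one ending in diethylamino. That match is seen in a 1.8-fold lower number from compound 2 to compound 4 (0.26 log units; within the scatter), and the change at the other end of the molecule, 1-hydroxy-2,2-dimethylpropyl for (tert-butyl)carbonyl, also leaves the two compounds unseparated in a 1.9-fold lower number from compound 1 to compound 4 (0.28 log units; within the scatter). No evidence on hand accounts for these steps.

Open, on these data alone, is whether the amine nitrogen is required: a 2-hydroxyethyl chain or a plain propyl chain on the amide nitrogen would test this. As far as these compounds go, a carboxylic acid at the chain end also remains open.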